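Replacing a Sulfone with an Ether on a Shared Core

The source may report more compounds than this note shows. Statements on the series, on what has been measured and on what is new or still open speak of the compounds shown alone.

Measured compounds:
compound 1, `Cc1ccc2ccc(-c3cc(O)cc(C#N)c3)cc2n1`: 360 nM
compound 2, `CCS(=O)(=O)c1cc(C#N)cc(-c2ccc3ccc(C)nc3c2)c1`: 1090 nM

In a functional assay on CHO cells for inhibition of metabotropic glutamate receptor 5 (Rattus norvegicus), read by FLIPR and calcium flux (on this read-out higher numbers stand for weaker inhibition and lower numbers for stronger inhibition), compound 1 gives 360 nM, while compound 2 gives 1090 nM. For the measured compounds named here, compound 2 therefore stands at the higher of the two numbers, the only measured step being a 3.0-fold higher number from compound 1 to compound 2 (0.48 log units; beyond the scatter). Compound 3, `Cc1ccc2ccc(-c3cc(C#N)cc(OCC(C)C)c3)cc2n1`, differs from compound 2 in one place: isobutoxy in place of ethylsulfonyl on an aromatic carbon. Going by the values given here, no measured step involves an isobutoxy group, so the only guide is the step between compound 1 and compound 2, which shows the ethylsulfonyl group sitting at the higher end of the two values. With the ethylsulfonyl group leaving, a modest move back toward the lower number is expected, roughly a 2.7-fold lower number from compound 2 to compound 3 (0.44 log units; beyond the scatter). For compound 3 the estimate in this assay is 400 nM, with a range from 120 nM to 1300 nM.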

Compound 3, half-maximal inhibitory concentration: 12000 nM
Beside the measured number, compound 3's estimate is 30-fold (1.48 log units) below it; the measured number lies above the stated range.
By their numbers in this assay, from the lowest: compound 1; then compound 2; then compound 3.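

At this position on the shared core, isobutoxy is the weakest of the three groups in this assay. Putting it in place of ethylsulfonyl brings an 11-fold higher number from compound 2 to compound 3 (1.04 log units; beyond the scatter) and putting isobutyl on the oxygen of the hydroxy compound brings a 33-fold higher number from compound 1 to compound 3 (1.52 log units; beyond the scatter), both far larger than the modest step the first two compounds had shown. Ethylsulfonyl and isobutoxy carry the same count of heavy atoms, so that count alone does not set the number here, and nothing measured on these compounds accounts for the drop.

As far as these compounds go, whether a smaller ether such as methoxy, or an amine, would stay close to compound 1 or fall toward compound 3 remains open. So does whether the branching matters, as the compounds shown include no straight butoxy chain.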